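The compounds below may be only part of what the source reports. "The series", "measured", "known", "first", "only" and "open" are said of these compounds alone.

Within the data shown here, compound 3 `COC(=O)c1nc(C)n(-c2ccc(F)cc2)n1` is the only member of this set that gives a number in a functional assay on Jurkat cells (Homo sapiens) for inhibition, read by MTT assay, with a stated time of 72 h; a higher number here means a weaker inhibitor of growth, a lower number a stronger inhibitor of growth: compound 3 gives 8700 nM. Compound 1 `COC(=O)c1nc(C)n(-c2ccccc2)n1` gives only a limit in this assay, > 100000 nM. Compound 2 `COC(=O)c1nc(C)n(-c2ccc(OC)cc2)n1` likewise gives only a limit, > 100000 nM. Both of these sit at the limit of > 100000 nM in this assay, at which 2 of the 3 values shown sit. The step of an at least 11-fold lower number from compound 1 to compound 3 (1.06 log units; beyond the scatter) and the step of an at least 11-fold lower number from compound 2 to compound 3 (1.06 log units; beyond the scatter) are therefore read against that limit, while the step that the two limits leave unreadable from compound 1 to compound 2 cannot be read at all. Compound 4 `COC(=O)c1nc(C(C)C)n(-c2ccc(F)cc2)n1` differs from compound 3 at a different place: isopropyl in place of methyl on an aromatic carbon. Among the measured compounds shown here, none of the measured steps touches this carbon; all three change the substituent that was hydrogen, methoxy or fluoro, and all three keep the methyl. For the measured compounds named here, there is thus no measured step that bears on the change from methyl to isopropyl, and the expectation can only be that compound 4 stays close to compound 3, with no step beyond the scatter in this assay but with wide uncertainty. Compound 4 is expected to give 8000 nM, between 2000 nM and 40000 nM. The step of a 1.1-fold lower number from compound 3 to compound 4 (0.04 log units; within the scatter) is an estimate, not a measurement.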

Compound 4, concentration for 50% growth inhibition: > 100000 nM
Compound 4 ended at the assay's limit; the forecaster's own chance of this, stated with the estimate: 10%; middle value at least 12-fold (1.09 log units) away from the limit.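

Among these compounds, the change from methyl to isopropyl gives an at least 11-fold higher number from compound 3 to compound 4 (1.06 log units; beyond the scatter) and is the first measured step at this carbon, so this position, held constant in all the earlier steps, also bears on the result. The fluoro group alone therefore does not secure a readable value: compound 4 keeps it, yet the number is lost on this one change. In this assay compound 4 gives only a limit, so the true size of the step stays unknown and the single number in the set still belongs to compound 3: the limit of > 100000 nM in this assay, at which 3 of the 4 values shown sit.

The compounds shown leave open whether ethyl or cyclopropyl at this carbon would keep a readable number, or whether hydrogen there would give a lower one. They also leave open how compound 3 would respond if a carboxylic acid or an amide replaced its methoxycarbonyl group.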